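The source may report more compounds than this note shows. Statements on the series, on what has been measured and on what is new or still open speak of the compounds shown alone.

Measured compounds:
compound 1, `C[C@@H]1CN(c2ncccc2C(F)(F)F)CCN1C(=O)Nc1ccc(C(F)(F)F)cc1` — 11 nM
compound 2, `O=C(Nc1ccccc1)c1ccc(-c2ncccc2C(F)(F)F)cc1` — "not determined" (no result reported)
compound 3, `Cc1cccnc1-c1ccc(C(=O)Nc2ccc(F)cc2)cc1` — > 4000 nM

Three compounds were examined in a functional assay for antagonist activity at transient receptor potential cation channel subfamily V member 1 (Rattus norvegicus); on this read-out higher numbers stand for weaker inhibition and lower numbers for stronger inhibition. Among the measured compounds shown here, compound 1 gives the only full number, 11 nM. Compound 2 carries no result in this assay. For compound 3 only a limit is recorded in this assay, > 4000 nM. Thus compound 3 stands at the limit named in the limit of > 4000 nM in this assay, at which 1 of the 3 values shown sits, and there is no measured step between any two compounds, since each of the three is built differently from the others.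

The unmeasured compound 4, `Cc1cccnc1-c1ccc(C(=O)Nc2ccc(C(C)(C)C)cc2)cc1`, is derived from compound 3 by the change tert-butyl in place of fluoro on an aromatic carbon. For the measured compounds named here, no measured pair shows the effect of such an exchange, so the size of the step in this assay is uncertain. Compound 4 is expected to be somewhat more potent than the limit of compound 3, the step of an at least 2.6-fold lower number from compound 3 to compound 4 (0.42 log units; beyond the scatter) being the estimate, though a result that again ends at a limit remains plausible. Compound 4 is therefore estimated at 1500 nM, within a range from 200 nM to 8000 nM.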

Compound 4, half-maximal inhibitory concentration: 9 nM
The estimate for compound 4 lay 170-fold (2.22 log units) above the measured number; the measured number lies below the stated range.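

In this assay, tert-butyl in place of fluoro on this aromatic carbon gives an at least 440-fold lower number from compound 3 to compound 4 (2.64 log units; beyond the scatter). Among the compounds shown here, this is the only pair here that differs in one place, and it shows that the group at this position, on the six-membered aromatic ring of carbon only, can by itself decide whether the shared core reads as a limit or as a full number. The exact size of the step cannot be read, since compound 3 has only a limit: the limit of > 4000 nM in this assay, at which 1 of the 4 values shown sits.

From the compounds shown here alone, whether an isopropyl group, a methoxy group or an amine at this position would keep the gain remains open, as only fluoro and tert-butyl are compared here. Also open, going by these compounds, is whether the same exchange would have a similar effect on the core of compound 1.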